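This account rests on a few compounds, and the source may have more. Where it says the series, first, only, none or still open, it means among the compounds named here.

Of the compounds shown here, two of a shared core have been measured in a functional assay on MDA-MB-435 cells (Homo sapiens) for inhibition, read by sulforhodamine B assay, with a stated time of 48 h; a lower number here means a stronger inhibitor of growth, a higher number a weaker inhibitor of growth. Compound 2, `COc1cc(-c2nn(-c3cccc(NC(=O)Nc4ccc(Cl)c(Cl)c4)c3)cc2-c2ccncc2)ccc1Cl`, gives 2390 nM and stands lowest of the two numbers. Compound 1, `O=C(Nc1cccc(-n2cc(-c3ccncc3)c(-c3ccc(Cl)c(O)c3)n2)c1)Nc1cccc(C(F)(F)F)c1`, gives 12600 nM, a higher number than compound 2 by a gap that lies beyond the scatter. Compound 1 and compound 2 differ in two places at once, so the comparison between them does not tell which change matters.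

Compound 3, `O=C(Nc1cccc(-n2cc(-c3ccncc3)c(-c3ccc(Cl)c(O)c3)n2)c1)Nc1ccc(Cl)c(Cl)c1`, has not been measured. It keeps the urea end of compound 2 and changes one thing: hydrogen in place of methyl on an oxygen on an aromatic ring. For the measured compounds named here, no measured pair shows this change on its own. Compound 1 carries the same hydroxy, but its different urea end means its value of 12600 nM cannot be read as the effect of the hydroxy alone.

For this step the expectation is a modest move toward a higher number, and it may well stay within the scatter: the step from compound 2 to compound 3 is estimated at a 1.7-fold higher number from compound 2 to compound 3 (0.22 log units; within the scatter). Compound 3 is therefore expected to give about 4000 nM in this assay, with a range from 1500 nM to 12000 nM.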

Compound 3, concentration for total growth inhibition: 6050 nM
Estimate against measurement, compound 3: 1.5-fold (0.18 log units) below, within the range that was stated.
By their numbers in this assay, from the lowest: compound 2; then compound 3; then compound 1.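

In this assay, the change from methoxy to hydroxy can now be read on its own, with the urea end held the same: the step is a 2.5-fold higher number from compound 2 to compound 3 (0.40 log units; beyond the scatter), so replacing the methyl on this oxygen with hydrogen modestly weakens growth inhibition. Compound 3 also pairs with compound 1, which carries the same hydroxy, so the urea end can be read alone as well: 3,4-dichlorophenyl in place of 3-(trifluoromethyl)phenyl on an amide-type nitrogen gives a 2.1-fold lower number from compound 1 to compound 3 (0.32 log units; beyond the scatter), showing that this change also moves the number by itself. Nothing available here explains why either change shifts the value.

What the compounds shown leave open is how this oxygen would behave with a longer chain such as ethoxy, or how the position would respond to an amine in place of the oxygen. The step from methoxy to hydroxy is also seen here with only the 3,4-dichlorophenyl urea end, and whether it has a similar size with the 3-(trifluoromethyl)phenyl end remains an open question.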